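The source may hold more compounds than are shown below. What is called first, only, known or untested is meant among the compounds shown, and "the series" means these compounds.

Of the compounds shown here, three in this set have been measured in a physicochemical assay for solubility; a higher number here means a more soluble compound, a lower number a less soluble compound. Compound 1 `CCCCCC(=O)n1c(=S)n(C(C)=O)c2ccccc21` gives 49000 nM, the lowest of the three. Compound 2 `CCCCCC(=O)n1c(=O)oc2ccccc21` gives 150000 nM, a higher value that lies nearest to compound 1 but still beyond the scatter. Compound 3 `COC(=O)c1ccc2oc(=S)n(C(=O)CCc3ccccc3)c2c1` gives 200000 nM, the furthest from compound 1, again beyond the scatter. For the measured compounds named here, the three cores differ in more than one place, so no single step between measured compounds can be drawn from them.

Compound 4 `CCCCCC(=O)n1c(=S)[nH]c2ccccc21` is not yet measured in this assay. It differs from compound 1 in one place: hydrogen in place of acetyl on an aromatic nitrogen. Nothing measured here shows what this change does on its own, so the expectation rests on compound 1 alone and on the direction such a change is usually taken to have. The step of a 2.4-fold higher number from compound 1 to compound 4 (0.39 log units; beyond the scatter) is expected to be a rise somewhat beyond the scatter. Compound 4 is estimated to give about 120000 nM in this assay, with a range from 50000 nM to 300000 nM.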

Compound 4, solubility: 170000 nM
Compound 4: the middle estimate sits 1.4-fold (0.15 log units) below what was measured, and the stated range covers the measured number.
By their numbers in this assay, from the lowest: compound 1; then compounds 2, 4 and 3 (each within the scatter of the next).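

In this assay, for the compounds shown here, this pair gives the first single-change comparison in the set: hydrogen in place of acetyl on an aromatic nitrogen produces a 3.5-fold higher number from compound 1 to compound 4 (0.54 log units; beyond the scatter), a modest step beyond the scatter. The earlier compounds shown here differed in more than one place and could not show whether this position affects the read-out, whereas here the rest of compound 1 stays unchanged and the number moves upward. No measurement shown gives a reason for this rise.

From the compounds shown here alone, the comparison covers only acetyl and hydrogen at this one position, so it remains open where a methyl group, a longer acyl chain or an amine-bearing chain would fall. Going by these compounds, it also remains open whether the same change would give a similar step on a different core.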